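Replacing the 4-bromophenyl group of compound 2

This account rests on a few compounds, and the source may have more. Where it says the series, first, only, none or still open, it means among the compounds named here.

In a functional assay on MGC-803 cells (Homo sapiens) for cytotoxicity, read by MTT assay, with a stated time of 72 h (on this read-out lower numbers stand for stronger inhibition and higher numbers for weaker inhibition), compound 1 `CC(C)=C1C(=O)N(c2ccc(Cl)cc2)N(c2ccc(Cl)cc2)C1=O` gives 39000 nM and compound 3 `CC(=C1C(=O)N(c2ccc(Cl)cc2)N(c2ccc(Cl)cc2)C1=O)c1ccc(O)cc1` gives 42800 nM while compound 2 `O=C1C(=Cc2ccc(Br)cc2)C(=O)N(c2ccc(Cl)cc2)N1c1ccc(Cl)cc1` gives 16900 nM as the lowest number of the three, beyond the scatter from both others. Compound 4 `COc1ccc(C=C2C(=O)N(c3ccc(Cl)cc3)N(c3ccc(Cl)cc3)C2=O)cc1OC` has not yet been measured. Its change from compound 2 (3,4-dimethoxyphenyl in place of 4-bromophenyl on a double-bonded chain carbon bound to a double-bonded ring carbon) swaps one substituted phenyl group for another on the shared core. For the measured compounds named here, the one measured step gives a 1.1-fold higher number from compound 1 to compound 3 (0.04 log units; within the scatter) when 4-hydroxyphenyl replaces methyl on a double-bonded chain carbon. That step does not test this swap directly, so no change beyond the scatter is expected. The estimate is a 1.3-fold higher number from compound 2 to compound 4 (0.11 log units; within the scatter) as the expected step. Compound 4 is expected to give 22000 nM with an estimated range of 9000 nM to 50000 nM once it is measured.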

Compound 4, half-maximal inhibitory concentration: > 128000 nM
Compound 4 gave a limit, no number; the forecaster's own chance of this, stated with the estimate: 10%; middle value at least 5.8-fold (0.76 log units) away from the limit.
By their numbers in this assay, from the lowest: compound 2; then compounds 1 and 3 (each within the scatter of the next). At a limit, above all of these: compound 4.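

In this assay, the phenyl group on a double-bonded chain carbon bound to a double-bonded ring carbon proves to matter: 3,4-dimethoxyphenyl in place of 4-bromophenyl gives an at least 7.5-fold higher number from compound 2 to compound 4 (0.87 log units; beyond the scatter), the first step shown that lies beyond the scatter. That size cannot be fixed, as the result for compound 4 is a limit and not a number: the limit of > 128000 nM in this assay, at which 1 of the 4 values shown sits. The compounds shown leave open whether a single methoxy group, as in 4-methoxyphenyl, would give the same result. From the compounds shown here alone, how a phenyl group carrying an amine or a carboxylic acid would read at this place also stays open.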